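Morpholine for Diisopropylamine on a Chromone Dithiocarbamate

The source may hold more compounds than are shown below. What is called first, only, known or untested is meant among the compounds shown, and "the series" means these compounds.

Three compounds have been measured in a functional assay on HEp-2 cells (Homo sapiens) for antiproliferative activity, read by MTT assay, with a stated time of 72 h; on this read-out higher numbers stand for weaker inhibition and lower numbers for stronger inhibition:

Compound 1, `CC(C)N(C(=S)SCc1cc(=O)c2ccc(Cl)cc2o1)C(C)C`, gives 22700 nM.
Compound 2, `O=c1cc(CSC(=S)N2CCOCC2)oc2cc(Cl)ccc12`, gives 20600 nM.
Compound 3, `CC(C)N(C(=S)SCc1cc(=O)c2ccccc2o1)C(C)C`, gives 13600 nM.

Two single changes connect these compounds. The first is morpholin-4-yl in place of diisopropylamino on a thiocarbonyl carbon, and it gave a 1.1-fold lower number from compound 1 to compound 2 (0.04 log units; within the scatter). The second is hydrogen in place of chloro on an aromatic carbon, and it gave a 1.7-fold lower number from compound 1 to compound 3 (0.22 log units; within the scatter). Compound 3 and compound 2 lie within the scatter of each other, so no order among the three can be claimed.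

The unmeasured compound 4, `O=c1cc(CSC(=S)N2CCOCC2)oc2ccccc12`, differs from compound 3 by morpholin-4-yl in place of diisopropylamino on a thiocarbonyl carbon. This is the same change that was made from compound 1 to compound 2, and the two places agree word for word. The two cores differ by hydrogen in place of chloro on an aromatic carbon.

Going by the values given here, compound 4 is expected to give a 1.1-fold lower number from compound 3 to compound 4 (0.04 log units; within the scatter), beside the earlier 1.1-fold lower number from compound 1 to compound 2 (0.04 log units; within the scatter); this rests on that earlier step alone, since only one other pair shows the change. Compound 4 is therefore estimated at 12500 nM, between 5500 nM and 28000 nM.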

Compound 4, half-maximal inhibitory concentration: > 25000 nM
Compound 4: only a limit was reported; the forecaster's own chance of this, stated with the estimate: 10%; at least 2.0-fold (0.30 log units) between middle value and limit.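

In this assay compound 4 gives > 25000 nM, which is a limit and not a number. Against that limit, morpholin-4-yl in place of diisopropylamino on a thiocarbonyl carbon gives an at least 1.8-fold higher number from compound 3 to compound 4 (0.26 log units; that floor lies within the scatter), and hydrogen in place of chloro on an aromatic carbon gives an at least 1.2-fold higher number from compound 2 to compound 4 (0.08 log units; that floor lies within the scatter). This does not show that the morpholin-4-yl change carries over from one core to the other unaltered, nor that it fails to carry over: the same change on two cores in this assay, a 1.1-fold lower number (0.04 log units; within the scatter) from compound 1 to compound 2 and an at least 1.8-fold higher number (0.26 log units; that floor lies within the scatter) from compound 3 to compound 4; the limit leaves it open whether they differ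

The compounds shown leave open what number compound 4 would give, and so whether either change acts differently on the two cores. They also leave open how other amines on the thiocarbonyl carbon, such as piperidin-1-yl or dimethylamino, or a fluoro or methoxy group in place of chloro on the aromatic carbon, would read in this assay.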